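Dichlorobenzimidazoles with a (2-hydroxyethoxy)methyl group

The compounds below may be only part of what the source reports. "The series", "measured", "known", "first", "only" and "open" are said of these compounds alone.

Measured so far:
compound 1 `OCCOCn1c(S)nc2cc(Cl)c(Cl)cc21` — > 100000 nM
compound 2 `OCCOCn1c(S)nc2c(Cl)cc(Cl)cc21` — > 100000 nM
compound 3 `OCCOCn1c(Br)nc2cc(Cl)c(Cl)cc21` — > 100000 nM

In a functional assay on KB cells (Homo sapiens) for inhibition (on this read-out higher numbers stand for weaker inhibition and lower numbers for stronger inhibition), compound 1 gives > 100000 nM, a limit of the assay and not a number. In this assay compound 2 gives > 100000 nM, also a limit. In this assay compound 3 gives > 100000 nM, again a limit. The change from compound 1 to compound 3 is bromo in place of sulfanyl on an aromatic carbon; the step that the two limits leave unreadable from compound 1 to compound 3 is not readable because of the limit of > 100000 nM in this assay, at which 3 of the 3 values shown sit. Compound 1 and compound 2 are built from the same atoms joined differently; the difference between the two cores is not broken down here. Compound 4 `OCCOCn1c(Br)nc2c(Cl)cc(Cl)cc21` repeats the same change, (bromo in place of sulfanyl on an aromatic carbon), on the core of compound 2. The step from compound 2 to compound 4 is expected to be a step that the limit leaves unreadable from compound 2 to compound 4, resting on the limit that compound 2 gives and the unreadable step from compound 1 to compound 3. Compound 4 is therefore estimated at 150000 nM in this assay, most likely reported again as a limit.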

Compound 4, half-maximal inhibitory concentration: > 100000 nM
Compound 4 was reported as a limit; the forecaster's own chance of this, stated with the estimate: 85%; the middle value lies beyond the limit too.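

No step can be read from compound 2 to compound 4 in this assay, as both sit at a limit: the limit of > 100000 nM in this assay, at which 4 of the 4 values shown sit.

The compounds shown leave open whether bromo in place of sulfanyl changes inhibition on either core.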